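Fluoro in place of methoxy: compound 3

The source may hold more compounds than are shown below. What is called first, only, known or untested is meant among the compounds shown, and "the series" means these compounds.

In a functional assay on MCF7 cells (Homo sapiens) for antiproliferative activity, read by MTT assay, with a stated time of 48 h (on this read-out higher numbers stand for weaker inhibition and lower numbers for stronger inhibition), compound 1 (`Cc1ccc(C(=O)/C=C/c2cc(Cl)cc(Cl)c2Oc2c([N+](=O)[O-])cc(C(F)(F)F)cc2[N+](=O)[O-])cc1`) gives 0.7 ug/mL and compound 2 (`COc1ccc(C(=O)/C=C/c2cc(Cl)cc(Cl)c2Oc2c([N+](=O)[O-])cc(C(F)(F)F)cc2[N+](=O)[O-])cc1`) gives 2.69 ug/mL, the higher of the two numbers. Compound 3 (`O=C(/C=C/c1cc(Cl)cc(Cl)c1Oc1c([N+](=O)[O-])cc(C(F)(F)F)cc1[N+](=O)[O-])c1ccc(F)cc1`) carries fluoro in place of methoxy on an aromatic carbon, para to a large group: fluoro in place of methoxy on an aromatic carbon. For the measured compounds named here, the one measured step on that carbon is a 3.8-fold higher number from compound 1 to compound 2 (0.58 log units; beyond the scatter), methoxy in place of methyl. Going by the values given here, no fluoro analogue has been measured, so that step offers only indirect guidance. The estimated step is a 1.8-fold lower number from compound 2 to compound 3 (0.25 log units; within the scatter), toward lower numbers and smaller than the measured one. For compound 3 the expected value in this assay is 1.5 ug/mL, with an estimated range of 0.6 ug/mL to 4 ug/mL.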

Compound 3, half-maximal inhibitory concentration: 5.02 ug/mL
Compound 3: middle estimate off by 3.3-fold (0.52 log units), on the low side; the measured number lies above the stated range.
By their numbers in this assay, from the lowest: compound 1; then compounds 2 and 3 (each within the scatter of the next).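

In this assay the change to fluoro leaves this aromatic carbon without a separable difference from methoxy, with a 1.9-fold higher number from compound 2 to compound 3 (0.27 log units; within the scatter) and thus within the scatter. Methyl now stands apart from both other groups, with a 7.2-fold higher number from compound 1 to compound 3 (0.86 log units; beyond the scatter) beyond the scatter, so compound 1 has the lowest number of the three. No evidence in hand bears on this result.

On these data alone, whether the advantage extends to a longer chain such as ethyl remains open. Also open, as far as these compounds go, is how an amine or a hydroxyl on this carbon would compare with methyl.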